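Acetylating the phenol of compound 2: an expected step

The source may report more compounds than this note shows. Statements on the series, on what has been measured and on what is new or still open speak of the compounds shown alone.

Measured compounds:
compound 1, `CCOC(=O)c1nn(-c2cccc(Cl)c2)c(=O)c2c(N)scc12`, 2 nM
compound 2, `CCOC(=O)c1nn(-c2ccc(O)cc2)c(=O)c2c(N)scc12`, 39.8 nM

In an in vitro functional assay on CHO cells for antagonist activity at adenosine receptor A1 (Homo sapiens), read by ERK phosphorylation (on this read-out higher numbers stand for weaker binding and lower numbers for tighter binding), compound 2 gives 39.8 nM, the higher of the two numbers recorded. Among the measured compounds shown here, the only measured step, a 20-fold higher number from compound 1 to compound 2 (1.30 log units; beyond the scatter), shows that changing the group on the aromatic nitrogen of the shared core moves the number a great deal. Compound 3, `CCOC(=O)c1nn(-c2ccc(OC(C)=O)cc2)c(=O)c2c(N)scc12`, keeps the 4-hydroxyphenyl arrangement of compound 2 but alters it: acetyl in place of hydrogen on an oxygen on an aromatic ring, so the hydroxy becomes acetoxy. For the measured compounds named here, no measured pair covers an acetyl on such an oxygen, so the measured step bears on it only by showing that this part of the molecule is sensitive. Compound 3 is therefore expected to differ from compound 2 by a moderate step of uncertain direction, a 1.6-fold lower number from compound 2 to compound 3 (0.20 log units; within the scatter), and its estimated value in this assay is 25 nM, within the range 6 nM to 100 nM.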

Compound 3, dissociation constant: 39.8 nM
The estimate for compound 3 lay 1.6-fold (0.20 log units) below the measured number; measured number inside the range.
By their numbers in this assay, from the lowest: compound 1; then compounds 2 and 3 (each within the scatter of the next).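

The step from hydroxy to acetoxy gives no change at the digits printed from compound 2 to compound 3 (within the scatter) in this assay, so the hydroxy hydrogen of compound 2 is not needed to keep the number at this level, and the three heavy atoms of the acetyl are accepted on that oxygen without a change beyond the scatter. The large earlier step, a 20-fold higher number from compound 1 to compound 2 (1.30 log units; beyond the scatter), had marked the group on the aromatic nitrogen as sensitive, but this result shows that not every change on that group moves the number. No available evidence explains why the acetyl leaves the number in place.

From the compounds shown here alone, whether a methyl ether or a longer acyl chain on the same oxygen would behave like the acetyl remains open. So does the effect of an amine or a carboxylic acid in place of the hydroxy.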